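Swapping Trifluoromethyl for Chloro on the Terminal Urea Aryl

The source may report more compounds than this note shows. Statements on the series, on what has been measured and on what is new or still open speak of the compounds shown alone.

In a functional assay on NCI-H460 cells (Homo sapiens) for inhibition, read by sulforhodamine B assay, with a stated time of 48 h, tested at 10 uM (a higher number here means a weaker effect of the compound at the concentration tested, a lower number a stronger effect), compound 1 `COc1cc2cc(Oc3ccc(NC(=O)Nc4ccccc4)cc3)c(C)nc2cc1OC` gives 69.1%. Compound 2 `COc1cc2cc(Oc3ccc(NC(=O)Nc4ccc(C(F)(F)F)cc4)cc3)c(C)nc2cc1OC` gives 42.8% in this assay, and compound 3 `COc1cc2cc(Oc3ccc(NC(=O)Nc4ccc(Cl)c(C(F)(F)F)c4)cc3)c(C)nc2cc1OC` gives -19.8%. Compound 3 therefore stands lowest of the three numbers, its nearest neighbour being compound 2 and its furthest compound 1. The measured steps leading to it were a number 26.3 percentage points lower from compound 1 to compound 2 (beyond the scatter), a number 88.9 percentage points lower from compound 1 to compound 3 (beyond the scatter) and a number 62.6 percentage points lower from compound 2 to compound 3 (beyond the scatter).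

Compound 4 `COc1cc2cc(Oc3ccc(NC(=O)Nc4ccc(Cl)c(Cl)c4)cc3)c(C)nc2cc1OC` differs from compound 3 by chloro in place of trifluoromethyl on an aromatic carbon. Within the data shown here, no measured step exchanges trifluoromethyl for chloro directly. The two large steps into compound 3 show that the 4-chloro-3-(trifluoromethyl)phenyl group carries the strong effect, but they do not separate the share of the chloro from the share of the trifluoromethyl, and the modest step from compound 1 to compound 2 shows that trifluoromethyl alone does only part of the work. Compound 4 keeps the chloro and a second substituent on that ring, so a strong effect is still expected, though the loss of trifluoromethyl may cost some of it. Compound 4 is therefore expected to give about 0%, somewhere between -30% and 35%. The expected step is a number 19.8 percentage points higher from compound 3 to compound 4 (beyond the scatter), a modest rise at most.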

Compound 4, a percentage reported as activity, at one concentration (the size of the read-out at that concentration, not a potency): 3.68%
Estimate against measurement, compound 4: 3.7 percentage points below; the measured number falls inside the stated range.
By their numbers in this assay, from the lowest: compound 3; then compound 4; then compound 2; then compound 1.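

Among these compounds, this is the first direct exchange at this place on the ring, ortho to a chloro group, and in this assay it gives a number 23.5 percentage points higher from compound 3 to compound 4 (beyond the scatter) which is beyond the scatter, so with the chloro kept, the trifluoromethyl is not interchangeable with a second chloro here. The exchange does not undo most of what the substituted ring achieves, however: the 3,4-dichlorophenyl group still accounts for a number 65.4 percentage points lower from compound 1 to compound 4 (beyond the scatter) and for a number 39.1 percentage points lower from compound 2 to compound 4 (beyond the scatter) so a strong effect at the tested concentration does not depend on trifluoromethyl being present on the terminal ring, and compound 2 shows that trifluoromethyl without the chloro falls well short of both disubstituted compounds. No measurement is available that would explain why the two groups differ at this position.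

On these data alone, what a single chloro gives on this ring by itself stays open, so the share of that group in the effect of compound 3 and compound 4 cannot be fixed. As far as these compounds go, it is also open how this place would respond to a fluoro, a methyl, a methoxy or a nitrile in place of the trifluoromethyl.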